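Adding 1-methyl-1H-pyrazol-4-yl to compound 2

A few compounds are considered here, and "the series" means these few. Any claim that something is new, unique, unknown or untested is made for them only; others in the source may bear on it.

In a functional assay on A549 cells (Homo sapiens) for inhibition, read by CCK-8 assay, with a stated time of 48 h (on this read-out lower numbers stand for stronger inhibition and higher numbers for weaker inhibition), compound 2 (`COc1cc(-c2ccnc3cc(-c4ccccc4)nn23)cc(OC)c1OC`) gives 208 nM. Within the data shown here, compound 1 (`COc1cc(-c2ccnc3cc(-c4ccc(C)c(C)c4)nn23)cc(OC)c1OC`) gives 272 nM, and the change is a 1.3-fold lower number from compound 1 to compound 2 (0.12 log units; within the scatter), which puts this pair together at the low end of the numbers so far. Compound 3 (`COc1cc(-c2ccnc3cc(-c4cccc(C)c4)nn23)cc(OC)c1OC`) gives 5730 nM, far from that pair.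

Compound 4 (`COc1cc(-c2ccnc3cc(-c4ccc(-c5cnn(C)c5)cc4)nn23)cc(OC)c1OC`) keeps the shared core and alters only the phenyl group of compound 2: 1-methyl-1H-pyrazol-4-yl in place of hydrogen on an aromatic carbon. The incoming 1-methyl-1H-pyrazol-4-yl group sits para to a large group.

The three measured steps all concern small changes on this same phenyl group, and they do not agree. Adding one methyl gives a 28-fold higher number from compound 2 to compound 3 (1.44 log units; beyond the scatter), and removing one methyl gives a 21-fold higher number from compound 1 to compound 3 (1.32 log units; beyond the scatter). Yet the 3,4-dimethylphenyl group of compound 1 shows only a 1.3-fold lower number from compound 1 to compound 2 (0.12 log units; within the scatter). Substitution here can therefore cost a great deal or almost nothing, and no measured compound carries a group as large as the one entering.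

A modest rise is expected, with real uncertainty in both directions. The estimated step is a 1.7-fold higher number from compound 2 to compound 4 (0.23 log units; within the scatter). For compound 4 the expected value is 350 nM, with an estimated range from 60 nM to 3000 nM.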

Compound 4, half-maximal inhibitory concentration: 1150 nM
For compound 4 the middle estimate is 3.3-fold (0.52 log units) below the measured one; low and high end bracket the measured number.
By their numbers in this assay, from the lowest: compounds 2 and 1 (each within the scatter of the next); then compound 4; then compound 3.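

In this assay, 1-methyl-1H-pyrazol-4-yl in place of hydrogen gives a 5.5-fold higher number from compound 2 to compound 4 (0.74 log units; beyond the scatter) and thus shows that a second aromatic ring, with its 6 heavy atoms, on the phenyl group of compound 2 weakens inhibition beyond the scatter, though only by a modest step. Adding one methyl gives a 28-fold higher number from compound 2 to compound 3 (1.44 log units; beyond the scatter) and so a larger step than this much bigger group, which means that among these compounds the size of the entering group does not set the size of the change, and compound 1, with its two methyl groups, also fits no simple rule of size. Nothing measured here accounts for the rise seen with compound 4.

The compounds shown leave open whether the rise belongs to the added ring as a whole or to its two nitrogen atoms, a question that a plain phenyl ring or an unmethylated pyrazole in the same place would help to settle. Going by these compounds, it also remains open how a dimethylamino group or a carboxylic acid would behave on this carbon.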